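This account rests on a few compounds, and the source may have more. Where it says the series, first, only, none or still open, it means among the compounds named here.

Compound 2 `CCCCCCCCCCCCCC(=O)N[C@@H](CO)C[C@@H](O)c1ccccc1` gives 70 nM in a functional assay on CHO cells (Cricetulus griseus) for inhibition; on this read-out higher numbers stand for weaker inhibition and lower numbers for stronger inhibition. Compound 1 `CCCCCCCCCCCCCCC(=O)N[C@@H](CO)C[C@@H](O)c1ccccc1` carries methyl in place of hydrogen on a saturated chain carbon, ten or more bonds along the chain from a carbonyl carbon, and in this assay compound 1 gives 90 nM, a change of a 1.3-fold higher number from compound 2 to compound 1 (0.11 log units; within the scatter). Compound 3 `CCCCCCCCCCCCCCCCC(=O)N[C@@H](CO)C[C@@H](O)c1ccccc1` differs from compound 2 by propyl in place of hydrogen on a saturated chain carbon, ten or more bonds along the chain from a carbonyl carbon. For compound 3 this assay reports only a limit, > 1000 nM, so its step from compound 1 is an at least 11-fold higher number from compound 1 to compound 3 (1.04 log units; beyond the scatter) and from compound 2 an at least 14-fold higher number from compound 2 to compound 3 (1.15 log units; beyond the scatter), both resting on (the limit of > 1000 nM in this assay, at which 1 of the 3 values shown sits). Compound 4 `CCCCCCCCCCCCCCCCCC(=O)N[C@@H](CO)C[C@@H](O)c1ccccc1` has not been measured; it differs from compound 3 by methyl in place of hydrogen on a saturated chain carbon, ten or more bonds along the chain from a carbonyl carbon, the same change as from compound 2 to compound 1. Since compound 3 already sits at the limit of > 1000 nM in this assay, at which 1 of the 3 values shown sits, compound 4 is expected to remain there, an estimated step that the limit leaves unreadable from compound 3 to compound 4, with an expected value of about 3000 nM, between 1000 nM and 10000 nM.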

Compound 4, half-maximal inhibitory concentration: > 1000 nM
Compound 4: a limit, no number; the forecaster's own chance of this, stated with the estimate: 85%; the middle value lies beyond the limit too.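

In this assay compound 4 gives > 1000 nM, which is a limit and not a number; compound 3 also stands at a limit, so the step between them cannot be read. The propyl change on the core of compound 1 gives an at least 11-fold higher number from compound 1 to compound 4 (1.04 log units; beyond the scatter), and the butyl change on the core of compound 2 gives an at least 14-fold higher number from compound 2 to compound 4 (1.15 log units; beyond the scatter), so the propyl change is large on both cores: the same change on two cores in this assay, an at least 14-fold higher number (1.15 log units; beyond the scatter) from compound 2 to compound 3 and an at least 11-fold higher number (1.04 log units; beyond the scatter) from compound 1 to compound 4; the limit leaves it open whether they differ The sizes of these changes remain unknown, and so does whether they match on the two cores, because they rest on a limit: the limit of > 1000 nM in this assay, at which 2 of the 4 values shown sit.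

The compounds shown leave open whether a shorter chain, a branched chain or a chain bearing a carboxylic acid would retain inhibition.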